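Bromo for phenyl: a second instance on a related core

This account rests on a few compounds, and the source may have more. Where it says the series, first, only, none or still open, it means among the compounds named here.

Compound 1 `CCCNC(=O)C1CC12CCN(C(=O)c1cc3sc(-c4ccccc4)nc3n1Cc1ccc(OC)cc1)CC2` and compound 2 `CCCNC(=O)C1CC12CCN(C(=O)c1cc3sc(Br)nc3n1Cc1ccc(OC)cc1)CC2` share one core and differ in a single place: bromo in place of phenyl on an aromatic carbon. In an ADME assay on microsomes from liver (Homo sapiens) for metabolic stability (a lower number here means that the compound disappears faster, a higher number that the compound lasts longer), compound 1 gives 0.697 h and compound 2 gives 0.0828 h, that is an 8.4-fold lower number from compound 1 to compound 2 (0.93 log units; beyond the scatter). Compound 3 `CCCNC(=O)C1CCN(C(=O)c2cc3sc(-c4ccccc4)nc3n2Cc2ccc(OC)cc2)CC1` sits on a second core; how it differs from compound 1 is not broken down here. In this assay compound 3 gives 0.68 h, which lies within the scatter of compound 1. Compound 4 `CCCNC(=O)C1CCN(C(=O)c2cc3sc(Br)nc3n2Cc2ccc(OC)cc2)CC1` is compound 3 carrying the same change, (bromo in place of phenyl on an aromatic carbon), at the same place. The step is expected to be an 8.2-fold lower number from compound 3 to compound 4 (0.91 log units; beyond the scatter) because an 8.4-fold lower number from compound 1 to compound 2 (0.93 log units; beyond the scatter) on the first core, which starts from a value within scatter of compound 3. Compound 4 is therefore estimated at 0.083 h, with a range from 0.04 h to 0.17 h.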

Compound 4, half-life: 0.0498 h
Compound 4: the middle estimate sits 1.7-fold (0.22 log units) above what was measured, and the stated range covers the measured number.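

In this assay bromo in place of phenyl on an aromatic carbon again goes with a shorter half-life (a 14-fold lower number from compound 3 to compound 4 (1.14 log units; beyond the scatter)), so the change carries from the core of compound 1 to the core of compound 3 with a step of similar size: the same change on two cores in this assay, an 8.4-fold lower number (0.93 log units; beyond the scatter) from compound 1 to compound 2 and a 14-fold lower number (1.14 log units; beyond the scatter) from compound 3 to compound 4, 1.6-fold (0.21 log units) apart, within the scatter of two such steps. Going by these compounds alone, this rests on only two matched pairs, which share all their other groups. It does not show that the step would hold on any further core, and it gives no reason for the shorter half-life.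

Open, going by these compounds, is how an amine, a methyl or a chloro at this aromatic carbon would compare with phenyl and bromo. Also open, on these data alone, is whether the step survives when the propyl chain on the amide gives way to a longer chain.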